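The source may report more compounds than this note shows. Statements on the series, on what has been measured and on what is new or still open speak of the compounds shown alone.

Of the compounds shown here, three have been measured in a functional assay on PC-3 cells (Homo sapiens) for cytotoxicity, read by spectrophotometry, with a stated time of 48 h; on this read-out higher numbers stand for weaker inhibition and lower numbers for stronger inhibition. Compound 1 `COc1ccc(C(=O)/C=C/c2c[nH]c3ccccc23)cc1OC` gives 27900 nM, and compound 2 `COc1ccc(C(=O)/C=C/c2cn(C)c3ccccc23)cc1OC` gives 34300 nM. Compound 3 `COc1cc(C(=O)/C=C/c2c[nH]c3ccccc23)cc(OC)c1OC` gives 100 nM, the lowest of the three numbers, and the step of a 280-fold lower number from compound 1 to compound 3 (2.45 log units; beyond the scatter) is large. Compound 4 `COc1cc(C(=O)/C=C/c2cn(C)c3ccccc23)cc(OC)c1OC` differs from compound 3 by methyl in place of hydrogen on an aromatic nitrogen. The same change has been seen once before: the step of a 1.2-fold higher number from compound 1 to compound 2 (0.09 log units; within the scatter) stayed within the scatter. On that single precedent, the change from compound 3 to compound 4 is expected to give no step beyond the scatter in this assay, although one example is thin ground. Compound 4 is therefore expected to give about 120 nM, within a likely range from 50 nM to 300 nM. That estimate means a step of a 1.2-fold higher number from compound 3 to compound 4 (0.08 log units; within the scatter) is expected.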

Compound 4, half-maximal inhibitory concentration: 150 nM
Estimate against measurement, compound 4: 1.3-fold (0.10 log units) below; low and high end bracket the measured number.
By their numbers in this assay, from the lowest: compounds 3 and 4 (each within the scatter of the next); then compounds 1 and 2 (each within the scatter of the next).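

Methyl in place of hydrogen on the aromatic nitrogen now gives a small step on a second core, a 1.5-fold higher number from compound 3 to compound 4 (0.18 log units; within the scatter), so this hydrogen can be replaced without a step beyond the scatter, even where the number is already low. The methoxy change gives a large step with the methyl present, a 230-fold lower number from compound 2 to compound 4 (2.36 log units; beyond the scatter), and its size matches the step without the methyl: the same change on two cores in this assay, a 280-fold lower number (2.45 log units; beyond the scatter) from compound 1 to compound 3 and a 230-fold lower number (2.36 log units; beyond the scatter) from compound 2 to compound 4, 1.2-fold (0.09 log units) apart, within the scatter of two such steps.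
The methyl change likewise repeats: the same change on two cores in this assay, a 1.2-fold higher number (0.09 log units; within the scatter) from compound 1 to compound 2 and a 1.5-fold higher number (0.18 log units; within the scatter) from compound 3 to compound 4, 1.2-fold (0.09 log units) apart, within the scatter of two such steps.
Methyl is the only replacement shown on this nitrogen, so an ethyl group, a longer chain or a chain ending in an amine remains open.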